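This account rests on a few compounds, and the source may have more. Where it says the series, first, only, none or still open, it means among the compounds named here.

In a functional assay on DU-145 cells (Homo sapiens) for inhibition, read by trypan blue exclusion, with a stated time of 96 h (a lower number here means a stronger inhibitor of growth, a higher number a weaker inhibitor of growth), compound 1 (`Cc1ccc(CS(=O)(=O)/C(=C/c2ccc(Br)cc2)C(=O)c2ccc(Cl)cc2)cc1`) gives 25000 nM, compound 2 (`Cc1ccc(CS(=O)(=O)/C(=C/c2cccc(Cl)c2Cl)C(=O)c2ccc(Cl)cc2)cc1`) gives 1000 nM and compound 3 (`Cc1ccc(S(=O)(=O)/C(=C/c2cc(C)ccc2C)C(=O)c2ccc(Cl)cc2)cc1`) gives 1000 nM. Compound 3 is thus level with compound 2, and together they hold the lowest number of the three. Compound 4 (`Cc1ccc(CS(=O)(=O)/C(=C/c2cc(C)ccc2C)C(=O)c2ccc(Cl)cc2)cc1`) differs from compound 3 in one place: 4-methylbenzyl in place of 4-methylphenyl on a sulfonyl sulfur, with 4-methylbenzyl in place of 4-methylphenyl on a sulfonyl sulfur. Going by the values given here, no measured step covers this change. The only one, a 25-fold lower number from compound 1 to compound 2 (1.40 log units; beyond the scatter), is large but lies at the group on the double-bonded chain carbon, so it shows only that the series can move widely. The data therefore give no direction, and no shift beyond the usual scatter is expected: the estimated change is a 1.5-fold higher number from compound 3 to compound 4 (0.18 log units; within the scatter). Compound 4 is estimated at 1500 nM, with an expected range of 300 nM to 10000 nM.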

Compound 4, concentration for 50% growth inhibition: 1000 nM
Compound 4: the middle estimate sits 1.5-fold (0.18 log units) above what was measured, within the range that was stated.
By their numbers in this assay, from the lowest: compounds 2, 3 and 4 (each within the scatter of the next); then compound 1.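

In this assay, going by these compounds alone, the swap of 4-methylphenyl for 4-methylbenzyl on a sulfonyl sulfur gives no change at the digits printed from compound 3 to compound 4 (within the scatter), the first reading of this position, which shows that it accepts this change with 2,5-dimethylphenyl on the double-bonded chain carbon. With 4-methylbenzyl held on the sulfur, 2,5-dimethylphenyl in place of 2,3-dichlorophenyl gives no change at the digits printed from compound 2 to compound 4 (within the scatter), and in place of 4-bromophenyl it gives a 25-fold lower number from compound 1 to compound 4 (1.40 log units; beyond the scatter), so the large step again lies at the group on the double-bonded chain carbon. No measurement at hand explains these results. Still open, as far as these compounds go, is whether a longer chain such as 2-phenylethyl on the sulfonyl sulfur would hold this level. Also open, from the compounds shown here alone, is whether 4-methylphenyl on that sulfur would match 4-methylbenzyl with 4-bromophenyl on the double-bonded chain carbon.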